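A few compounds are considered here, and "the series" means these few. Any claim that something is new, unique, unknown or untested is made for them only; others in the source may bear on it.

Working notes on the series

Compound 1 `COc1ccc(NC(=O)c2cc(N(C)Cc3ccccc3)ncn2)cc1` is the reference compound here. In an ADME assay on Vero cells (Chlorocebus sabaeus) for cytotoxicity, read by MTT assay (on this read-out higher numbers stand for weaker inhibition and lower numbers for stronger inhibition), compound 1 gives 287000 nM. Compound 2 `CN(Cc1ccccc1)c1cc(C(=O)Nc2ccccc2)ncn1` differs from compound 1 by methoxy in place of hydrogen on an aromatic carbon; in this assay compound 2 gives 314000 nM, and the step of a 1.1-fold higher number from compound 1 to compound 2 (0.04 log units; within the scatter). Compound 3 `CN(Cc1ccc(F)cc1)c1cc(C(=O)Nc2ccccc2)ncn1` carries the change (fluoro in place of hydrogen on an aromatic carbon); in this assay compound 3 gives 297000 nM, and the step of a 1.1-fold lower number from compound 2 to compound 3 (0.02 log units; within the scatter). All three numbers lie within the scatter of one another, so no order among them is claimed.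

Compound 4 `COc1ccc(NC(=O)c2cc(N(C)Cc3cccc(F)c3)ncn2)cc1` is not yet measured. It differs from compound 1 by fluoro in place of hydrogen on an aromatic carbon. Going by the values given here, this is the same kind of change as the one from compound 2 to compound 3, but not the same: in compound 3 the fluoro sits para to a large group, in compound 4 it sits meta to a large group. Since the earlier step of a 1.1-fold lower number from compound 2 to compound 3 (0.02 log units; within the scatter) stayed within the scatter, a step of similar size is expected from compound 1 to compound 4 in this assay, namely a 1.0-fold lower number from compound 1 to compound 4 (0.00 log units; within the scatter). On that basis compound 4 is estimated at 285000 nM, with an expected range from 200000 nM to 400000 nM.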

Compound 4, half-maximal inhibitory concentration in the Vero assay: 272000 nM
For compound 4 the middle estimate is 1.0-fold (0.02 log units) above the measured one; measured number inside the range.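

In the Vero assay the new step, a 1.1-fold lower number from compound 1 to compound 4 (0.02 log units; within the scatter), stands beside the earlier fluoro step on the other core, and the two agree: the same change on two cores in the Vero assay, a 1.1-fold lower number (0.02 log units; within the scatter) from compound 2 to compound 3 and a 1.1-fold lower number (0.02 log units; within the scatter) from compound 1 to compound 4, 1.0-fold (0.00 log units) apart, within the scatter of two such steps. This shows that fluoro in place of hydrogen on an aromatic carbon left the number within the scatter on both cores, but it does not show that any effect carries from one core to the other, since neither step can be told from no change and the fluoro does not sit in the same place in compound 3 and compound 4. In a physicochemical assay for solubility, using the shake flask method, measured as kinetic solubility, with a stated time of 2 h, at pH 7.4 (on this read-out lower numbers stand for lower solubility and higher numbers for higher solubility), compound 1 gives < 5000 nM, which is a limit of the assay and not a number, so the step to compound 4 cannot be read: the limit of < 5000 nM in the physicochemical assay, at which 1 of the 2 values shown sits. In the physicochemical assay compound 4 gives 5000 nM.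

Still open, on these data alone, is whether 3-fluorobenzyl on the core of compound 2 would read as it does on the core of compound 1. Also open, as far as these compounds go, is whether a group other than fluoro on that ring, such as an amine or a carboxylic acid, would move the number in the Vero assay beyond the scatter.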